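From compound 1 to compound 3: a carbonyl enters

A few compounds are considered here, and "the series" means these few. Any claim that something is new, unique, unknown or untested is made for them only; others in the source may bear on it.

In a functional assay on SGC-7901 cells (Homo sapiens) for antiproliferative activity, read by MTT assay, with a stated time of 24 h (a lower number here means a stronger inhibitor, a higher number a weaker inhibitor), compound 1 (`O=C(NNc1ccccc1Cl)c1ccccc1NS(=O)(=O)c1cnc(O)nc1O`) gives > 20000 nM as its reading, which is a limit of the assay and not a number. Compound 2 (`Cc1ccc(C(=O)NNC(=O)c2ccc(NS(=O)(=O)c3cnc(O)nc3O)cc2)cc1`) gives > 20000 nM as its reading, again a limit. The evidence so far is therefore the limit of > 20000 nM in this assay, at which 2 of the 2 values shown sit, and no true number. Compound 3 (`O=C(NNC(=O)c1ccccc1NS(=O)(=O)c1cnc(O)nc1O)c1ccccc1Cl`) differs from compound 1 by one change, (2-chlorophenyl)carbonyl in place of 2-chlorophenyl on an amine nitrogen. Among the measured compounds shown here, no measured step is available as a guide, so the expected a number no higher from compound 1 to compound 3 (the limit leaves the size open) is none beyond the scatter in this assay and another limit is the likeliest reading. Compound 3 is estimated at 20000 nM as a central value, with an expected range from 7000 nM to 40000 nM in this read-out.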

Compound 3, half-maximal inhibitory concentration: 2410 nM
Estimate against measurement, compound 3: 8.3-fold (0.92 log units) above; measured number below the stated range.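

In this assay the exchange of 2-chlorophenyl for (2-chlorophenyl)carbonyl on the amine nitrogen gives an at least 8.2-fold lower number from compound 1 to compound 3 (0.91 log units; beyond the scatter) and is the only step shown so far. Compound 3 thus carries the first true number among the compounds shown, and this position is the first place in the series where a single change is seen to move the reading beyond the scatter. The other readings remain limits, which bound the comparison: the limit of > 20000 nM in this assay, at which 2 of the 3 values shown sit.

Going by these compounds, whether the carbonyl alone accounts for the step, or whether it depends on the 2-chlorophenyl group it carries, stays open. Also open, on these data alone, is whether an acetyl or a sulfonyl-linked phenyl on the same nitrogen would keep a true number in this assay and how far the reading would shift.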